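The compounds below may be only part of what the source reports. "The series", "measured", "known", "first", "only" and "open" are said of these compounds alone.

Compound 2 `COc1cc(COc2cc(N)c(Cl)cc2C(=O)CCCCN2CCC(C)CC2)cc(OC)c1` carries the shared core of this small set. In a functional assay for antagonist activity at 5-hydroxytryptamine receptor 4 (Rattus norvegicus) (on this read-out lower numbers stand for lower potency and higher numbers for higher potency (the scale is a negative logarithm)), compound 2 gives 8.3, which is the second highest of the three numbers measured. Its nearest neighbour is compound 1 `COc1ccc(COc2cc(N)c(Cl)cc2C(=O)CCCCN2CCCCC2)cc1OC`, which in this assay gives 8.5; the two values sit within the scatter of each other. Furthest from it is compound 3 `CCCC1CCN(CCCCC(=O)c2cc(Cl)c(N)cc2OCc2cc(OC)cc(OC)c2)CC1`, which in this assay gives 7.7, and here the difference is beyond the scatter: a number 0.60 log units lower from compound 2 to compound 3 (beyond the scatter).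

Compound 4 `COc1cc(COc2cc(N)c(Cl)cc2C(=O)CCCCN2CCC(C(N)=O)CC2)cc(OC)c1` has not yet been measured in this assay. It differs from compound 2 in one place: carbamoyl in place of methyl on a saturated ring carbon. For the measured compounds named here, no measured step alters that same ring carbon in the same way. Going by the values given here, the only step at that position, the one from compound 2 to compound 3, was a modest loss, and it enlarged the group there as this change also does. The step from compound 2 to compound 4 is therefore expected to be a number 0.40 log units lower from compound 2 to compound 4 (beyond the scatter), a small loss that may still fall within the scatter. Compound 4 is accordingly estimated to give 7.9 in this assay, with a range from 7.2 to 8.6.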

Compound 4, negative logarithm of the antagonist equilibrium constant: 8.4
Compound 4: middle estimate off by 0.50 log units, on the low side; the range from low to high includes it.
By their numbers in this assay, from the lowest: compound 3; then compounds 2, 4 and 1 (each within the scatter of the next).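

In this assay, the saturated ring carbon three ring bonds from the ring nitrogen accepts carbamoyl in place of methyl, with a number 0.10 log units higher from compound 2 to compound 4 (within the scatter), even though the group grows from one heavy atom to three and brings a hydrogen-bond donor and acceptor. Replacing propyl with carbamoyl at the same carbon gives a number 0.70 log units higher from compound 3 to compound 4 (beyond the scatter), so the loss seen with propyl does not extend to every group larger than methyl at this position. Nothing available explains why these two larger groups part ways.

The compounds shown leave open whether a carboxylic acid, a primary amine or a hydroxyl at this ring carbon would behave like carbamoyl or like propyl. They also leave open whether an amide bearing a methyl on its nitrogen, or a longer chain ending in carbamoyl, would keep the same standing.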